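Swapping the ring on the amide carbonyl of a shared core

This account rests on a few compounds, and the source may have more. Where it says the series, first, only, none or still open, it means among the compounds named here.

Of the compounds shown here, two built on the same core have been tested so far. Compound 1 `COc1cc(N(C)C)c(NC(=O)c2ccnc(Cl)c2)cc1Nc1nccc(-c2cn(C)c3ccccc23)n1` carries a 2-chloropyridin-4-yl group on the amide carbonyl carbon; in a functional assay on A549 cells (Homo sapiens) for antiproliferative activity, read by MTT assay, with a stated time of 72 h (on this read-out lower numbers stand for stronger inhibition and higher numbers for weaker inhibition), compound 1 gives 3430 nM. Compound 2 `COc1cc(N(C)C)c(NC(=O)c2ncccn2)cc1Nc1nccc(-c2cn(C)c3ccccc23)n1` differs only in that ring, and in this assay compound 2 gives 8640 nM. Going by the values given here, the single step measured so far, a 2.5-fold higher number from compound 1 to compound 2 (0.40 log units; beyond the scatter), shows that changing this ring shifts the read-out by a modest amount. Compound 2 therefore stands with the highest number of the two, meaning the weaker inhibition.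

Compound 3 `COc1cc(N(C)C)c(NC(=O)c2c[nH]cn2)cc1Nc1nccc(-c2cn(C)c3ccccc23)n1` takes the change one step further: 1H-imidazol-4-yl in place of pyrimidin-2-yl on a carbonyl carbon. Among the compounds with values here, no step with this five-membered ring has been measured, so the only guide is the modest size of the step from compound 1 to compound 2, which suggests that ring swaps at this position move the number by small amounts rather than large ones. For compound 3 the expectation in this assay is therefore a step of a 1.2-fold lower number from compound 2 to compound 3 (0.09 log units; within the scatter), not beyond the scatter, giving an estimated 7000 nM within the range 2500 nM to 20000 nM.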

Compound 3, half-maximal inhibitory concentration: 3560 nM
Compound 3: middle estimate off by 2.0-fold (0.29 log units), on the high side; measured number inside the range.
By their numbers in this assay, from the lowest: compounds 1 and 3 (each within the scatter of the next); then compound 2.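

In this assay the five-membered 1H-imidazol-4-yl ring on the carbonyl carbon brings the number back down, with a 2.4-fold lower number from compound 2 to compound 3 (0.39 log units; beyond the scatter) as a second modest step beyond the scatter. The comparison with the chlorinated ring gives a 1.0-fold higher number from compound 1 to compound 3 (0.02 log units; within the scatter) and lies within the scatter, so a five-membered ring and a six-membered ring can occupy this place on the amide carbonyl with no readable difference between them. Ring size alone therefore does not sort these compounds, since compound 1 and compound 2 both carry six-membered aromatic rings yet their numbers stand apart, while compound 3 with its smaller ring matches compound 1.

From the compounds shown here alone, all three groups on this carbonyl are aromatic rings containing nitrogen, so how a plain phenyl ring, a saturated amine such as piperidine or a short alkyl chain would read at the same place remains open. The data also offer no explanation of why pyrimidin-2-yl stands apart from the other two rings.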